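The compounds below may be only part of what the source reports. "The series", "measured", "known", "first", "only" and "open" are said of these compounds alone.

Compound 3 `CC(=O)c1ccc(-c2cn3ccnc3c(-c3ccc4ncn(C5CCCCC5)c4c3)n2)cc1` stands lowest of the three values in a functional assay on NCI-H522 cells (Homo sapiens) for inhibition, read by sulforhodamine B assay, with a stated time of 48 h, tested at 10 uM (a higher number here means more inhibition at the concentration tested (going by the name of the read-out), a lower number less inhibition), so far: compound 3 gives 10.4%, whereas compound 1 `c1ccc(-c2cn3ccnc3c(-c3ccc4ncn(C5CCCCC5)c4c3)n2)cc1` gives 58.1% and compound 2 `Fc1ccc(-c2cn3ccnc3c(-c3ccc4ncn(C5CCCCC5)c4c3)n2)cc1` gives 15.5%. The change toward compound 4 `Clc1ccc(-c2cn3ccnc3c(-c3ccc4ncn(C5CCCCC5)c4c3)n2)cc1` is chloro in place of acetyl on an aromatic carbon. Bearing on it are the steps of a number 42.6 percentage points lower from compound 1 to compound 2 (beyond the scatter), a number 47.7 percentage points lower from compound 1 to compound 3 (beyond the scatter) and a number 5.1 percentage points lower from compound 2 to compound 3 (within the scatter): both groups placed at this position fall far from compound 1, and the two substituted compounds sit within scatter of each other. Chloro is, like fluoro, a halogen at the same position, so compound 4 is expected near compound 2 and compound 3, a step of a number 4.6 percentage points higher from compound 3 to compound 4 (within the scatter) only, not beyond scatter. Compound 4 is estimated at 15%, range 0% to 40%.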

Compound 4, a percentage reported as inhibition, at one concentration (the size of the read-out at that concentration, not a potency): 19.8%
Compound 4: middle estimate off by 4.8 percentage points, on the low side; measured number inside the range.
By their numbers in this assay, from the lowest: compounds 3, 2 and 4 (each within the scatter of the next); then compound 1.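

In this assay the 4-chlorophenyl compound also lies far from the unsubstituted one (a number 38.3 percentage points lower from compound 1 to compound 4 (beyond the scatter)), so all three groups at this position now fall well short of compound 1. Chloro cannot be separated from acetyl (a number 9.4 percentage points higher from compound 3 to compound 4 (within the scatter)) or from fluoro (a number 4.3 percentage points higher from compound 2 to compound 4 (within the scatter)), although acetyl and chloro differ in heavy atoms and hydrogen-bond acceptors. No measured evidence bears on why these groups read alike.

Open, as far as these compounds go, is whether any substituent at this position keeps the level of compound 1, for example an amine, a methoxy group or a carboxylic acid.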